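The compounds below may be only part of what the source reports. "The series", "measured", "known", "first", "only" and "open" are said of these compounds alone.

Of the compounds shown here, three of a shared core have been measured in an assay for inhibition of histone-lysine N-methyltransferase, H3 lysine-79 specific (Homo sapiens), read by scintillation counting, with stated times of 15 min and 60 min, tested at 50 uM, in the presence of a further agent that is not named here; a higher number here means a stronger effect of the compound at the concentration tested, a lower number a weaker effect. Compound 1, with the structure `Cc1occc1-c1nnc2sc(Cc3ccccc3)nn12`, gives 13%. Compound 2, with the structure `Fc1cccc(-c2nnc3sc(/C=C/c4ccco4)nn23)c1`, gives 22%. Compound 3, with the structure `c1ccc2c(Cc3nn4c(-c5ccoc5)nnc4s3)cccc2c1`, gives 59%, the highest of the three numbers.

Compound 2 stands second highest of the three. Its nearest neighbour is compound 1, whose number is lower by a gap within the usual scatter, so the two cannot be told apart; its furthest is compound 3, whose number is higher by a gap beyond the scatter.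

The compound still to be measured is compound 4, with the structure `Fc1ccc(-c2nnc3sc(/C=C/c4ccco4)nn23)cc1`. It differs from compound 2 at a single position: 4-fluorophenyl in place of 3-fluorophenyl on an aromatic carbon. The atoms are the same; only the point where the fluorine sits on the six-membered ring of carbon changes.

Within the data shown here, no pair of measured compounds shows a step of this kind, so there is nothing to lean on beyond the three numbers themselves. Moving a fluorine from one position on the phenyl to another is a small change, and the expected step in this assay from compound 2 to compound 4 is none beyond the scatter, in either direction, as expressed by a number 2 percentage points higher from compound 2 to compound 4 (within the scatter). Compound 4 is accordingly estimated to give 24% in this assay, with a range from 5% to 45%.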

Compound 4, a percentage reported as inhibition, at one concentration (the size of the read-out at that concentration, not a potency): 44%
Beside the measured number, compound 4's estimate is 20 percentage points below it, within the range that was stated.
By their numbers in this assay, from the lowest: compounds 1 and 2 (each within the scatter of the next); then compound 4; then compound 3.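

In this assay, 4-fluorophenyl in place of 3-fluorophenyl, on the aromatic carbon of the five-membered ring, gives a number 22 percentage points higher from compound 2 to compound 4 (beyond the scatter), a modest step and the first in this set that isolates a single change. The two groups are the same in every count, with the same atoms and the same ring, so the point where the fluorine sits on the phenyl is the only difference, and it is enough to move the read-out beyond the usual scatter at the one concentration tested. This is a difference in effect at that concentration rather than in potency, and nothing given here accounts for it.

The compounds shown leave open whether the fluorine itself contributes anything, since a plain phenyl does not appear in this set, and whether a chlorine atom or a methoxy group on the same ring would follow the same course between the two positions. Among these compounds, they also leave open whether the step carries over to the rest of the series, since compound 1 and compound 3 differ from compound 4 in more than one place and offer no matching pair.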